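A few compounds are considered here, and "the series" means these few. Any claim that something is new, unique, unknown or untested is made for them only; others in the source may bear on it.

Measured so far:
- compound 1, `Cc1ccc(C2=NN(C3=NC(=O)CS3)C(c3ccc4ccccc4c3)C2)cc1`: 1760 nM
- compound 2, `Cc1ccc(C2=NN(C3=NC(c4ccccc4)CS3)C(c3ccc4ccccc4c3)C2)cc1`: 2460 nM
- compound 3, `COc1ccc(C2=NN(C3=NC(=O)CS3)C(c3cccc4ccccc34)C2)cc1`: 2540 nM

In a functional assay on HeLa cells (Homo sapiens) for inhibition, read by CCK-8 assay, with a stated time of 48 h (on this read-out lower numbers stand for stronger inhibition and higher numbers for weaker inhibition), compound 2 gives 2460 nM, the second highest of the three numbers. Its nearest neighbour is compound 3, and the gap between the two is within the scatter; compound 1 lies furthest from it, and that gap is also within the scatter. Among the compounds with values here, the one step with a single change, a 1.4-fold higher number from compound 1 to compound 2 (0.15 log units; within the scatter), alters the group on the amine nitrogen in a ring and moves the number by an amount within the scatter. Compound 3 differs from compound 1 in more than one place, so its number is noted without reading a step from it.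

Compound 4, `Cc1ccc(C2=NN(C3=NC(c4ccccc4)CS3)C(c3ccc4ccccc4c3)C2)cc1C`, differs from compound 2 as follows: methyl in place of hydrogen on an aromatic carbon. The change sits on the 4-methylphenyl, which becomes 3,4-dimethylphenyl. Within the data shown here, no measured step touches this ring, so nothing bears directly on it. Among the measured compounds shown here, the one step that is known was small, and a single methyl added at this place is expected to leave the number within the scatter of compound 2.

For compound 4 the estimated value is 2400 nM, with a range from 1200 nM to 5000 nM; the expected step from compound 2 is a 1.0-fold lower number from compound 2 to compound 4 (0.01 log units; within the scatter).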

Compound 4, half-maximal inhibitory concentration: 950 nM
Compound 4: middle estimate off by 2.5-fold (0.40 log units), on the high side, and the stated range ends above it.
By their numbers in this assay, from the lowest: compounds 4, 1, 2 and 3 (each within the scatter of the next, the first and the last beyond it).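

In this assay, the 4-methylphenyl is a place where a single added atom registers: the change to 3,4-dimethylphenyl gives a 2.6-fold lower number from compound 2 to compound 4 (0.41 log units; beyond the scatter), a modest step beyond the scatter. The only earlier single-place step, on the amine nitrogen in a ring, was a 1.4-fold higher number from compound 1 to compound 2 (0.15 log units; within the scatter), so this is the first change in the series shown to move the number beyond the scatter. Nothing available explains the shift.

As far as these compounds go, it remains open whether a chlorine atom, a methoxy group or an ethyl group on the same aromatic carbon, ortho to the methyl group, would give a similar step. From the compounds shown here alone, it is equally open whether the 3,4-dimethylphenyl change would carry over to the core of compound 1, which has a carbonyl in place of the phenyl-bearing ring.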